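Enlarging the Ester of an Adenosine A2b Binder

A few compounds are considered here, and "the series" means these few. Any claim that something is new, unique, unknown or untested is made for them only; others in the source may bear on it.

Measured compounds:
Compound 1 `COC(=O)C1=C(C)NC(=O)NC1c1ccoc1`: 42%
Compound 2 `COC(=O)C1=C(C)N(C)C(=O)NC1c1ccoc1`: 7%

In an assay on membranes from HEK293 cells for displacement of a labelled ligand from adenosine receptor A2b (Homo sapiens), read by scintillation counting, with a stated time of 30 min, tested at 1 uM (a lower number here means less inhibition, a higher number more inhibition at the concentration tested (going by the name of the read-out)), compound 1 gives 42%, while compound 2 gives 7%. Among the measured compounds shown here, the one step measured so far, a number 35 percentage points lower from compound 1 to compound 2 (beyond the scatter), came from putting methyl in place of hydrogen on an amide-type nitrogen in a ring. For the measured compounds named here, compound 2 therefore stands at the lowest of the two numbers known, and its only neighbour, compound 1, lies higher by a margin beyond the scatter.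

Compound 3 `CC1=C(C(=O)OC(C)C)C(c2ccoc2)NC(=O)N1C` differs from compound 2 in a different place: isopropyl in place of methyl on an oxygen next to a carbonyl group. Going by the values given here, no measured step touches this oxygen; the recorded step from compound 1 to compound 2 concerns the ring nitrogen and says nothing about the ester. With no evidence pointing either way, the step of a number 1 percentage points higher from compound 2 to compound 3 (within the scatter) is expected to stay within the usual scatter, in no particular direction. Compound 3 is thus estimated at 8%, with a range from 0% to 25% to allow for the absence of any guiding step.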

Compound 3, a percentage reported as inhibition, at one concentration (the size of the read-out at that concentration, not a potency): 37%
Compound 3: the middle estimate sits 29 percentage points below what was measured; measured number above the stated range.
By their numbers in this assay, from the lowest: compound 2; then compounds 3 and 1 (each within the scatter of the next).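

In this assay, the ester turns out to be a place that matters: isopropyl in place of methyl on an oxygen next to a carbonyl group gives a number 30 percentage points higher from compound 2 to compound 3 (beyond the scatter) and so marks this oxygen's substituent as a second place where a small change alters the read-out. Among the compounds shown here, the direction is opposite to that of the only earlier step, on the ring nitrogen, which gave a number 35 percentage points lower from compound 1 to compound 2 (beyond the scatter) and so the low number of compound 2 does not hold once the methyl on the oxygen gives way to isopropyl, even with the methyl on the ring nitrogen still in place. No measurement available here explains why the swap from methoxy to isopropoxy raises the number.

The compounds shown leave open whether the number keeps following the ester group, for instance with a longer chain such as butyl, a bulkier tert-butyl or a free carboxylic acid at this place. They also leave open whether isopropyl would give a similar step on the core of compound 1, which keeps the amide hydrogen.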